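A few compounds are considered here, and "the series" means these few. Any claim that something is new, unique, unknown or untested is made for them only; others in the source may bear on it.

Measured in a functional assay on HT cells (Homo sapiens) for antiproliferative activity, read by fluorescence, with a stated time of 72 h; a higher number here means a weaker inhibitor of growth, a lower number a stronger inhibitor of growth:
Compound 1 `CC(C)c1n[nH]c2c(NCc3ccc(-c4ccccn4)cc3)nc(SCCO)nc12`: 48 nM
Compound 2 `CC(C)c1n[nH]c2c(NCc3ccc(-c4ccccn4)cc3)nc(SCC(C)(C)O)nc12`: 507 nM

Of these two compounds, compound 2 has the higher number in this assay, at 507 nM, and so is the weaker inhibitor of growth. Compound 3 `CC(C)c1n[nH]c2c(NCc3ccc(-c4ccccn4)cc3)nc(SCC(O)CN)nc12` keeps the shared core and changes only the chain on sulfur, with 2-amino-1-hydroxyethyl in place of 1-hydroxy-1-methylethyl on a saturated chain carbon bound to a sulfur.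

Among the compounds with values here, only one measured step bears on this change. It is an 11-fold higher number from compound 1 to compound 2 (1.02 log units; beyond the scatter), and it came with 1-hydroxy-1-methylethyl in place of hydroxymethyl at that same place. Compound 3 gives up the group that compound 2 gained in that step, but it does not return to hydroxymethyl, and neither measured compound carries an amino group. Only part of that large step is therefore expected to be recovered.

The expected change is a 3.9-fold lower number from compound 2 to compound 3 (0.59 log units; beyond the scatter), towards a lower number but with real uncertainty. Compound 3 is estimated at 130 nM, with an expected range of 40 nM to 420 nM.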

Compound 3, concentration for 50% growth inhibition: 55 nM
For compound 3 the middle estimate is 2.4-fold (0.37 log units) above the measured one; the measured number falls inside the stated range.
By their numbers in this assay, from the lowest: compounds 1 and 3 (each within the scatter of the next); then compound 2.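

In this assay, the chain on sulfur turns out to depend strongly on which groups it carries, not only on how many atoms they contain: 2-amino-1-hydroxyethyl and 1-hydroxy-1-methylethyl count the same 4 heavy atoms, yet the exchange gives a large shift (a 9.2-fold lower number from compound 2 to compound 3 (0.96 log units; beyond the scatter)). The position also accepts more than the small hydroxymethyl chain, since the added aminomethyl leaves the number within the scatter (a 1.1-fold higher number from compound 1 to compound 3 (0.06 log units; within the scatter)), so a longer chain on sulfur does not by itself bring the loss seen with compound 2. The two methyl groups of compound 2 therefore stand out as the feature that goes with its weaker inhibition of growth among these three compounds, although nothing available here explains that link.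

What the compounds shown leave open is whether the amine of compound 3 has any effect of its own, or whether it is simply accommodated alongside the hydroxyl. A chain ending in a carboxylic acid, a 3-aminopropyl chain without the hydroxyl, or a single methyl group on the carbinol carbon would each test a different part of this picture.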